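Cyano in place of isopropoxy: from compound 2 to compound 3

A few compounds are considered here, and "the series" means these few. Any claim that something is new, unique, unknown or untested is made for them only; others in the source may bear on it.

Going by the values given here, compound 2 `CC(C)Oc1cc(=O)oc2cc(OCc3cccc(Cl)c3)ccc12` stands at the higher of the two numbers measured so far: in an assay on isolated protein (strain Sprague-Dawley) for inhibition of Amine oxidase [flavin-containing] B (Rattus norvegicus), read by spectrophotometry, with a stated time of 5 min (on this read-out lower numbers stand for stronger inhibition and higher numbers for weaker inhibition), compound 2 gives 24500 nM. Among the compounds with values here, its only neighbour, compound 1 `CCOc1cc(=O)oc2cc(OCc3cccc(F)c3)ccc12`, differs from it in two places, and in this assay compound 1 gives 263 nM, a far lower number. Within the data shown here, no single step between measured compounds is known, so the gap between compound 1 and compound 2 cannot be assigned to either of the two changes.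

Compound 3 `N#Cc1cc(=O)oc2cc(OCc3cccc(Cl)c3)ccc12` is not yet measured. It keeps the rest of compound 2 and changes one place: cyano in place of isopropoxy on an aromatic carbon. Among the measured compounds shown here, the group that enters is the smaller one, counted by heavy atoms, and the only measured compound with a smaller group at that place, compound 1, gives the lower number, though it differs elsewhere as well.

On this footing a step toward a lower number is expected, beyond the scatter yet short of the whole gap to compound 1. For compound 3 the value in this assay is estimated at 2500 nM, with a range from 300 nM to 15000 nM, which means an expected step of a 9.8-fold lower number from compound 2 to compound 3 (0.99 log units; beyond the scatter).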

Compound 3, half-maximal inhibitory concentration: 102 nM
Estimate against measurement, compound 3: 25-fold (1.39 log units) above; the measured number lies below the stated range.
By their numbers in this assay, from the lowest: compound 3; then compound 1; then compound 2.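

In this assay, going by these compounds alone, the exchange of isopropoxy for cyano brings a 240-fold lower number from compound 2 to compound 3 (2.38 log units; beyond the scatter) and is the first change that can be tied to a single place, since the rest of the molecule stays the same. This place, on an aromatic carbon opposite the ring oxygen, therefore has a large bearing on the number in this pair of compounds. Cyano and isopropoxy have the same count of hydrogen-bond acceptors and donors, so those counts do not separate them, whereas they do differ in heavy atoms and in the triple bond, and no measurement at hand explains the size of the step.

With a single pair, the compounds shown cannot tell whether the lower number goes with the smaller group or with something particular to cyano, and a methyl group, an amine or a carboxylic acid at the same place would help to separate these readings. From the compounds shown here alone, it also remains open whether the step would keep its size with fluoro in place of chloro, as in compound 1, which differs from compound 3 in more than one place.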